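Heteroaryl swap on the cycloheptanol amide series

The source may report more compounds than this note shows. Statements on the series, on what has been measured and on what is new or still open speak of the compounds shown alone.

Compound 1 `Cc1cnc(-c2ccc(Cl)c(C(=O)NCC3(O)CCCCCC3)c2)cn1` holds the lowest number of the three measured compounds in a functional assay on HEK293 cells for antagonist activity at P2X purinoceptor 7 (Homo sapiens) (a higher number here means a weaker inhibitor, a lower number a stronger inhibitor), giving 22 nM. Compound 3 `O=C(NCC1(O)CCCC(F)(F)CC1)c1cc(-c2ncc(F)cn2)ccc1Cl` gives 46 nM in this assay, a step beyond the scatter, and compound 2 `O=C(NCC1(O)CCCC1)c1cc(-c2ncc(F)cn2)ccc1Cl` gives 449 nM, the furthest from compound 1. Compound 4 `O=C(NCC1(O)CCCCCC1)c1cc(-c2ccc(Cl)cn2)ccc1Cl` is not yet measured; it keeps the core of compound 1 and differs by 5-chloropyridin-2-yl in place of 5-methylpyrazin-2-yl on an aromatic carbon. Among the compounds with values here, no measured pair isolates this swap, so nothing in hand sets its size. Both groups are single six-membered aromatic rings of the same heavy-atom count, so only a small step is expected, a 1.1-fold lower number from compound 1 to compound 4 (0.04 log units; within the scatter), likely within the scatter in either direction. Compound 4 is therefore estimated at 20 nM in this assay, with a range of 7 nM to 60 nM.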

Compound 4, half-maximal inhibitory concentration: 56 nM
Compound 4: the middle estimate sits 2.8-fold (0.45 log units) below what was measured, and the stated range covers the measured number.
By their numbers in this assay, from the lowest: compound 1; then compounds 3 and 4 (each within the scatter of the next); then compound 2.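

At this aromatic carbon, 5-chloropyridin-2-yl in place of 5-methylpyrazin-2-yl gives a 2.5-fold higher number from compound 1 to compound 4 (0.41 log units; beyond the scatter) in this assay. Two rings of equal heavy-atom count are therefore not interchangeable here, even with the rest of compound 1 held fixed. No measured property in hand accounts for this step.

The swap changes the ring hetero atoms and the ring substituent together, so the two contributions stay unseparated. As far as these compounds go, a 5-chloropyrazin-2-yl or 5-methylpyridin-2-yl group at this carbon would divide the step between them, and what either would give remains open.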